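Amino to dimethylamino on the side chain

The source may hold more compounds than are shown below. What is called first, only, known or untested is meant among the compounds shown, and "the series" means these compounds.

In a functional assay on HCT-8 cells (Homo sapiens) for antiproliferative activity, read by MTT assay, with a stated time of 48 h (on this read-out lower numbers stand for stronger inhibition and higher numbers for weaker inhibition), compound 1 `COc1ccc(C(=O)c2ccc(OC)c3c2OC(C)(C)C=C3)c(NC(=O)CN)c1` gives 370 nM and compound 2 `C=C(c1ccc(OC)cc1NC(=O)CN)c1ccc(OC)c2c1OC(C)(C)C=C2` gives 190 nM, so compound 2 stands within the scatter of compound 1. Compound 3 `C=C(c1ccc(OC)cc1NC(=O)CN(C)C)c1ccc(OC)c2c1OC(C)(C)C=C2` differs from compound 2 in one place: dimethylamino in place of amino on a saturated chain carbon bound to a carbonyl carbon. Within the data shown here, no measured step covers this change, so the expectation rests on compound 2 at 190 nM. The expected step of a 1.5-fold higher number from compound 2 to compound 3 (0.17 log units; within the scatter) in this assay is small, towards weaker inhibition, and may stay within the scatter. For compound 3 the estimated value is 280 nM, with an expected range from 80 nM to 950 nM.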

Compound 3, half-maximal inhibitory concentration: 690 nM
For compound 3 the middle estimate is 2.5-fold (0.39 log units) below the measured one; low and high end bracket the measured number.
By their numbers in this assay, from the lowest: compounds 2, 1 and 3 (each within the scatter of the next, the first and the last beyond it).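

On the side chain, dimethylamino in place of amino gives a 3.6-fold higher number from compound 2 to compound 3 (0.56 log units; beyond the scatter) in this assay. Among these compounds, this is the first measured step at this saturated chain carbon bound to a carbonyl carbon, and it shows that the read-out responds to a change in the terminal amine here, towards weaker inhibition. Nothing available explains this step.

From the compounds shown here alone, whether methylamino or a cyclic amine such as pyrrolidine would fall nearer compound 2 or compound 3 remains open. Going by these compounds, it is also open whether the same step would hold on the core of compound 1.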